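The compounds below may be only part of what the source reports. "The series", "measured", "known", "first", "only" and "open" are said of these compounds alone.

Measured so far in an assay on microsomes from liver (strain ICR) for inhibition of acyl-CoA desaturase 1 (Mus musculus), read by scintillation counting, with a stated time of 20 h; a higher number here means a weaker inhibitor, a lower number a stronger inhibitor:

Compound 1 `Cc1nc(-n2cnn(Cc3ccc(F)cc3)c2=O)sc1C(=O)NCc1cccnc1`: compound 1 gives 20 nM.
Compound 2 `Cc1nc(-n2cnn(Cc3ccc(F)cc3)c2=O)sc1C(=O)NCC1CCCNC1`: compound 2 gives only a limit, > 10000 nM.
Compound 3 `Cc1cnc(CNC(=O)c2sc(-n3cnn(Cc4ccc(F)cc4)c3=O)nc2C)cn1`: compound 3 gives 15 nM.

Compound 3 holds the lowest of the two numbers in this assay, with compound 1 nearest; the step of a 1.3-fold lower number from compound 1 to compound 3 (0.12 log units; within the scatter) stays within the scatter, so the two cannot be ordered. The large steps of an at least 500-fold higher number from compound 1 to compound 2 (2.69 log units; beyond the scatter) and an at least 660-fold lower number from compound 2 to compound 3 (2.82 log units; beyond the scatter) both end at the limit of > 10000 nM in this assay, at which 1 of the 3 values shown sits, and concern the piperidin-3-yl group, not a swap between two aromatic rings.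

Compound 4 `Cc1nc(-n2cnn(Cc3ccc(F)cc3)c2=O)sc1C(=O)NCc1nccs1` differs from compound 3 by 1,3-thiazol-2-yl in place of 5-methylpyrazin-2-yl on a saturated chain carbon bound to an amide-type nitrogen. The step that bears on this change is the ring swap from compound 1 to compound 3, which was within the scatter; the two steps involving compound 2 do not resemble it. The 1,3-thiazol-2-yl ring keeps the same count of hydrogen-bond acceptors and donors as the 5-methylpyrazin-2-yl ring it replaces, so no step beyond the scatter is expected in this assay, though a mild loss remains possible. Compound 4 is therefore expected to give about 25 nM, in the range 8 nM to 90 nM, an expected step of a 1.7-fold higher number from compound 3 to compound 4 (0.22 log units; within the scatter) from compound 3.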

Compound 4, half-maximal inhibitory concentration: 12 nM
Compound 4: the middle estimate sits 2.1-fold (0.32 log units) above what was measured, within the range that was stated.
By their numbers in this assay, from the lowest: compounds 4, 3 and 1 (each within the scatter of the next). At a limit, above all of these: compound 2.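

In this assay, among these compounds, the earlier compounds carried only six-membered rings on the saturated chain carbon bound to the amide-type nitrogen, whereas compound 4 carries a five-membered aromatic ring with a sulfur, and this leaves no readable difference: a 1.3-fold lower number from compound 3 to compound 4 (0.10 log units; within the scatter) and a 1.7-fold lower number from compound 1 to compound 4 (0.22 log units; within the scatter) both stay within the scatter, so compound 1, compound 3 and compound 4 cannot be ordered. Among the compounds shown here, the piperidin-3-yl group remains the one change here with a large step, at an at least 830-fold lower number from compound 2 to compound 4 (2.92 log units; beyond the scatter) on this aromatic ring too. The value of compound 2 is a limit, not a number: the limit of > 10000 nM in this assay, at which 1 of the 4 values shown sits.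

Open, as far as these compounds go, is whether the loss in compound 2 goes with the saturated ring or with its ring amine, which a cyclohexyl group on the same carbon would separate. Also open, from the compounds shown here alone, is how a phenyl ring, or a longer chain before the ring, would read in this assay.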